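Swapping an Amide for Chlorine in a Cytotoxicity Test

The compounds below may be only part of what the source reports. "The series", "measured", "known", "first", "only" and "open" are said of these compounds alone.

Among the compounds with values here, compound 1 `O=C(c1ccc(NCc2cncn2Cc2ccc(-c3ccccc3)cc2)cc1-c1ccccc1)N1CCCCC1` is one of three compounds measured in a toxicity assay on NIH3T3 cells (Mus musculus) for cytotoxicity, read by resazurin assay; a lower number here means that less compound is needed, a higher number that more compound is needed for the effect. In this assay compound 1 gives > 1000 nM, which is a limit of the assay and not a number. Compound 2 `CCc1ccc(Cn2cncc2CNc2ccc(-c3nc4ccccc4s3)c(-c3ccccc3)c2)cc1` likewise gives > 1000 nM, a limit. Compound 3 `Cc1cccc(-c2cc(NCc3cncn3Cc3ccc(-c4ccccc4)cc3)ccc2-c2nc3ccccc3s2)c1C` gives > 1000 nM, also a limit. All three values therefore sit at the same limit, as shown by the limit of > 1000 nM in this assay, at which 3 of the 3 values shown sit, and no compound can be placed above or below another on these numbers.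

Compound 4 `Clc1ccc(NCc2cncn2Cc2ccc(-c3ccccc3)cc2)cc1-c1ccccc1` has not yet been measured. It differs from compound 1 in one place: chloro in place of (piperidin-1-yl)carbonyl on an aromatic carbon. Within the data shown here, no step between two measured compounds is known here, so no measured step shows how large a change such a swap brings. With every measured value resting at the same limit, the expectation for compound 4 is a value that again reaches only that limit, estimated at 3000 nM, within 1000 nM to 10000 nM. In this assay the change is expected to be a step that the limit leaves unreadable from compound 1 to compound 4, nothing beyond the scatter.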

Compound 4, half-maximal effective concentration: > 1000 nM
Compound 4 gave a limit, no number; the forecaster's own chance of this, stated with the estimate: 85%; the middle value lies beyond the limit too.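

Compound 1 and compound 4 both end at a limit rather than a number, so no step can be read between them: the limit of > 1000 nM in this assay, at which 4 of the 4 values shown sit.

The compounds shown leave open how much of any of them this assay would need for the effect, and whether the chloro swap changes that amount.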